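Halogen pattern on the phenyl ring and kinase inhibition

A few compounds are considered here, and "the series" means these few. Any claim that something is new, unique, unknown or untested is made for them only; others in the source may bear on it.

Measured compounds:
- compound 1, `O=C(O)CC(Cc1nc2cc(Cl)ccc2[nH]1)c1ccc(Cl)cc1`; in an assay on isolated protein for inhibition of protein kinase C zeta type (Homo sapiens), read by 33P incorporation, tested at 50 uM (on this read-out lower numbers stand for a weaker effect and higher numbers for a stronger effect at the one concentration tested), compound 1 gives 0%
- compound 2, `Cc1ccc2[nH]c(CC(CC(=O)O)c3ccc(Cl)cc3)nc2c1`; in this assay compound 2 gives 0%
- compound 3, `O=C(O)CC(Cc1nc2cc(Cl)ccc2[nH]1)c1ccc(Cl)c(F)c1`; in this assay compound 3 gives 0%

Compound 3 stands level with compounds 1 and 2 at the digits printed, all three at the floor of the read-out. The step from compound 1 to compound 3, fluoro in place of hydrogen on an aromatic carbon, gave no change at the digits printed from compound 1 to compound 3 (within the scatter). The step from compound 1 to compound 2, methyl in place of chloro on an aromatic carbon of the shared core, gave no change at the digits printed from compound 1 to compound 2 (within the scatter).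

Compound 4, `O=C(O)CC(Cc1nc2cc(Cl)ccc2[nH]1)c1ccc(Cl)cc1Cl`, is the next member. Relative to compound 3 the change is 2,4-dichlorophenyl in place of 4-chloro-3-fluorophenyl on a saturated chain carbon bound to two saturated chain carbons.

Of the measured steps, no change at the digits printed from compound 1 to compound 3 (within the scatter) is the one that bears on this change, as it also alters the halogen pattern on the phenyl ring attached to the saturated chain carbon; no change at the digits printed from compound 1 to compound 2 (within the scatter) touches the core instead. For the measured compounds named here, both steps stayed within the scatter, and no compound has left the floor. A third change of the same kind is therefore expected to give no step beyond the scatter, no change at the digits printed from compound 3 to compound 4 (within the scatter). For compound 4 the estimate is 0%, expected to fall between -5% and 10%.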

Compound 4, a percentage reported as inhibition, at one concentration (the size of the read-out at that concentration, not a potency): 30%
Estimate against measurement, compound 4: 30 percentage points below, and the stated range ends below it.
By their numbers in this assay, from the lowest: compounds 1, 2 and 3 (each within the scatter of the next); then compound 4.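

In this assay, for the compounds shown here, the phenyl ring on the saturated chain carbon bound to two saturated chain carbons is the first place where a change lifts the read-out off the floor: a further chloro on this ring gives a number 30 percentage points higher from compound 1 to compound 4 (beyond the scatter), and 2,4-dichlorophenyl in place of 4-chloro-3-fluorophenyl gives a number 30 percentage points higher from compound 3 to compound 4 (beyond the scatter). Adding a halogen to this ring does not by itself bring the gain, as the fluoro step gave no change at the digits printed from compound 1 to compound 3 (within the scatter), so the result depends on which halogen pattern enters. Nothing available here accounts for the gain.

From the compounds shown here alone, it remains open whether a bromo, methyl or methoxy group in place of the entering chloro would hold the gain. Also open, going by these compounds, is whether 2,4-dichlorophenyl would give the same gain on the methyl-bearing core of compound 2, or with an amide in place of the carboxylic acid.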